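The source may report more compounds than this note shows. Statements on the series, on what has been measured and on what is new or still open speak of the compounds shown alone.

Measured in a functional assay on KBVIN cells (Homo sapiens) for antiproliferative activity, read by sulforhodamine B assay, with a stated time of 3 days; a higher number here means that more compound is needed for the effect, a lower number that less compound is needed:
- Compound 1 `CCC1=C(O)c2c(oc(-c3ccc(CBr)cc3)cc2=O)C(CC)(CC)C1=O`: 27.9 uM
- Compound 2 `CCC1=C(O)c2c(oc(-c3ccc(C)c(Cl)c3)cc2=O)C(CC)(CC)C1=O`: 2.15 uM
- Compound 3 `CCC1=C(O)c2c(oc(-c3ccc(O)c(O)c3)cc2=O)C(CC)(CC)C1=O`: 5.41 uM

Compound 3 sits in the middle of these three numbers, with a 2.5-fold higher number from compound 2 to compound 3 (0.40 log units; beyond the scatter) on one side and a 5.2-fold lower number from compound 1 to compound 3 (0.71 log units; beyond the scatter) on the other. The next compound, compound 4 `CCC1=C(O)c2c(oc(-c3cc(C)c(O)c(C)c3)cc2=O)C(CC)(CC)C1=O`, keeps the shared core and changes one group, with 4-hydroxy-3,5-dimethylphenyl in place of 3,4-dihydroxyphenyl on an aromatic carbon next to the ring oxygen: 4-hydroxy-3,5-dimethylphenyl in place of 3,4-dihydroxyphenyl on an aromatic carbon.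

The new group has a hydroxy group, as in compound 3, and methyl groups, as the group in compound 2 has one methyl. The most useful guide is therefore the modest step of a 2.5-fold higher number from compound 2 to compound 3 (0.40 log units; beyond the scatter). The larger steps of a 13-fold lower number from compound 1 to compound 2 (1.11 log units; beyond the scatter) and a 5.2-fold lower number from compound 1 to compound 3 (0.71 log units; beyond the scatter) both start from the 4-(bromomethyl)phenyl group, which compound 4 lacks, so they say less here. Only a small move towards a lower number is expected, an estimated 1.5-fold lower number from compound 3 to compound 4 (0.19 log units; within the scatter). For compound 4 the estimated value is 3.5 uM, with an expected range from 1.5 uM to 9 uM.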

Compound 4, concentration for half-maximal effect: 8.9 uM
The estimate for compound 4 lay 2.5-fold (0.41 log units) below the measured number, within the range that was stated.
By their numbers in this assay, from the lowest: compound 2; then compounds 3 and 4 (each within the scatter of the next); then compound 1.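

Replacing 3,4-dihydroxyphenyl with 4-hydroxy-3,5-dimethylphenyl gives a 1.6-fold higher number from compound 3 to compound 4 (0.22 log units; within the scatter) in this assay, so this position takes one hydroxy group fewer and two methyl groups more with no difference that can be told from the scatter. Compound 4 still stands apart from the other two groups, with a 4.1-fold higher number from compound 2 to compound 4 (0.62 log units; beyond the scatter) and a 3.1-fold lower number from compound 1 to compound 4 (0.50 log units; beyond the scatter), which leaves 3-chloro-4-methylphenyl with the lowest number of the four and 4-(bromomethyl)phenyl with the highest. Nothing available here explains why these groups differ.

The hydroxy and methyl changes arrive together in compound 4, so the compounds shown cannot separate what each one contributes. On these data alone, it also stays open how this position would respond to an amine, a carboxylic acid or a longer chain on the phenyl ring.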